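A second chloro added to compound 2

The source may hold more compounds than are shown below. What is called first, only, known or untested is meant among the compounds shown, and "the series" means these compounds.

Compound 2 `CN(C)CCNc1nc(-c2ccc(NC(=O)Nc3ccccc3Cl)cc2)nc2ccsc12` is the member of the pair that carries one chloro. Among the compounds with values here, in a functional assay on MDA-MB-231 cells (Homo sapiens) for cytotoxicity, read by MTT assay, with a stated time of 72 h (a higher number here means a weaker inhibitor, a lower number a stronger inhibitor), compound 2 gives 550 nM, the lowest of the two numbers measured so far. Within the data shown here, its nearest neighbour is compound 1 `CN(C)CCNc1nc(-c2ccc(NC(=O)Nc3ccccc3)cc2)nc2ccsc12`, which lacks that chloro and in this assay gives 1310 nM; the only measured step, a 2.4-fold lower number from compound 1 to compound 2 (0.38 log units; beyond the scatter), separates them.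

Compound 3 `CN(C)CCNc1nc(-c2ccc(NC(=O)Nc3ccc(Cl)cc3Cl)cc2)nc2ccsc12` differs from compound 2 by the change (chloro in place of hydrogen on an aromatic carbon). Among the measured compounds shown here, the single step that bears on this, a 2.4-fold lower number from compound 1 to compound 2 (0.38 log units; beyond the scatter), is a change of the same kind, chloro in place of hydrogen on an aromatic carbon, and its size was modest. Whether a second chloro repeats that gain is not shown by anything measured; with one chloro already in place, the further change is expected to move the number in the same direction but by less. The step expected from this is a 1.5-fold lower number from compound 2 to compound 3 (0.17 log units; within the scatter). Compound 3 is therefore estimated at 370 nM in this assay, with a range from 150 nM to 1100 nM.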

Compound 3, half-maximal inhibitory concentration: 2450 nM
Compound 3: middle estimate off by 6.6-fold (0.82 log units), on the low side; the measured number lies above the stated range.
By their numbers in this assay, from the lowest: compound 2; then compounds 1 and 3 (each within the scatter of the next).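

In this assay the chloro that turns 2-chlorophenyl into 2,4-dichlorophenyl gives a 4.5-fold higher number from compound 2 to compound 3 (0.65 log units; beyond the scatter) and so runs opposite to the first chloro, which gave a 2.4-fold lower number from compound 1 to compound 2 (0.38 log units; beyond the scatter) on the same ring. Replacing hydrogen with chloro on this ring therefore has no fixed direction across the compounds shown, and the new position, para to a large group and meta to a chloro group, is one where the number moves up from that of compound 2. With both chloro groups in place, a 1.9-fold higher number from compound 1 to compound 3 (0.27 log units; within the scatter) leaves the dichloro compound not told apart from the unsubstituted phenyl, so the advantage of compound 2 is not kept. Nothing measured here accounts for this reversal.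

The compounds shown do not separate the effect of the position itself from that of the chloro already on the ring, as none carries a chloro para to a large group without the other chloro. Also open, as far as these compounds go, is whether a smaller fluoro or a methoxy group at that position would follow the chloro.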